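The source may report more compounds than this note shows. Statements on the series, on what has been measured and on what is new or still open speak of the compounds shown alone.

Compound 1 `CNC(=O)c1sc2ncccc2c1N` stands in an assay on isolated protein for inhibition of LIM domain kinase 1 (Homo sapiens), read by Kinase-Glo, with a stated time of 60 min (a higher number here means a weaker inhibitor, a lower number a stronger inhibitor), at a limit of the assay rather than at a number: compound 1 gives > 100000 nM. Compound 2 `Nc1c(C(=O)O)sc2ccccc12` sits at the same limit, since in this assay compound 2 gives > 100000 nM, again a limit. Both results fall where the limit of > 100000 nM in this assay, at which 2 of the 2 values shown sit, places them. Compound 3 `Nc1c(C(=O)O)sc2ncccc12` differs from compound 1 by hydroxy in place of methylamino on a carbonyl carbon. For the measured compounds named here, no measured step between compounds is available, so the expected step from compound 1 to compound 3 is a step that the limit leaves unreadable from compound 1 to compound 3, nothing beyond the scatter. Compound 3 is therefore estimated at 150000 nM, within 50000 nM to 500000 nM, most likely reported once more only as a limit.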

Compound 3, half-maximal inhibitory concentration: > 100000 nM
Compound 3 ended at the assay's limit; the forecaster's own chance of this, stated with the estimate: 85%; the middle value is on the limit's open side.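

Compound 1 and compound 3 both stand at a limit rather than at a number, so no step between them can be read: the limit of > 100000 nM in this assay, at which 3 of the 3 values shown sit.

The compounds shown leave open whether hydroxy in place of methylamino on a carbonyl carbon changes anything in this assay.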